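Extending the ester chain of compound 3 by one carbon

The compounds below may be only part of what the source reports. "The series", "measured", "known", "first", "only" and "open" are said of these compounds alone.

Compound 3, with the structure `CCCCCCCCCCCCCCOC(=O)CCC(=O)N1CCN(CCCOc2cc3c(Nc4ccc(F)c(Cl)c4)ncnc3cc2OC)CC1`, gives 88.6% in a functional assay on A549 cells (Homo sapiens) for cytotoxicity, read by MTT assay, with a stated time of 24 h, tested at 40 uM (a higher number here means a weaker effect of the compound at the concentration tested, a lower number a stronger effect), the highest of the three numbers measured, so the weakest effect at this concentration. Compound 1, `CCCCCCCCOC(=O)CCC(=O)N1CCN(CCCOc2cc3c(Nc4ccc(F)c(Cl)c4)ncnc3cc2OC)CC1`, gives 48.7%, and compound 2, `CCCCCCCCCOC(=O)CCC(=O)N1CCN(CCCOc2cc3c(Nc4ccc(F)c(Cl)c4)ncnc3cc2OC)CC1`, gives 17.9%. Compound 4, `CCCCCCCCCCCCCCCOC(=O)CCC(=O)N1CCN(CCCOc2cc3c(Nc4ccc(F)c(Cl)c4)ncnc3cc2OC)CC1`, differs from compound 3 by methyl in place of hydrogen on a saturated chain carbon, ten or more bonds along the chain from an oxygen next to a carbonyl group. Among the measured compounds shown here, the steps that bear on a one-carbon extension of this chain point in both directions: a number 30.8 percentage points lower from compound 1 to compound 2 (beyond the scatter), whereas a number 39.9 percentage points higher from compound 1 to compound 3 (beyond the scatter) and a number 70.7 percentage points higher from compound 2 to compound 3 (beyond the scatter). No single direction is established, but the longest chain so far carries the highest number. Compound 4 is therefore expected to stay near compound 3, with an estimated step of a number 3.6 percentage points lower from compound 3 to compound 4 (within the scatter), giving an estimate of 85% with a range from 55% to 100%.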

Compound 4, a percentage reported as activity, at one concentration (the size of the read-out at that concentration, not a potency): 85.5%
Beside the measured number, compound 4's estimate is 0.5 percentage points below it, and the stated range covers the measured number.
By their numbers in this assay, from the lowest: compound 2; then compound 1; then compounds 4 and 3 (each within the scatter of the next).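

In this assay, methyl in place of hydrogen on a saturated chain carbon gives a number 3.1 percentage points lower from compound 3 to compound 4 (within the scatter), so at this chain length the added carbon leaves the read-out unchanged within the scatter. Compound 4 also stands clear of the shorter esters, with a number 67.6 percentage points higher from compound 2 to compound 4 (beyond the scatter) and a number 36.8 percentage points higher from compound 1 to compound 4 (beyond the scatter). The same one-carbon addition therefore reads differently at the two chain lengths: the same change on two cores in this assay, a number 30.8 percentage points lower (beyond the scatter) from compound 1 to compound 2 and a number 3.1 percentage points lower (within the scatter) from compound 3 to compound 4, 27.7 percentage points apart, beyond the scatter of two such steps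

Where between the chains of compound 2 and compound 3 the number turns upward remains open. So does what a longer chain, or an amine on this chain, would give.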